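The compounds below may be only part of what the source reports. "The series", "measured", "known", "first", "only" and "open" are said of these compounds alone.

Measured so far in a functional assay on MCF7 cells (Homo sapiens) for inhibition, read by MTT assay, with a stated time of 72 h, tested at 30 uM; on this read-out higher numbers stand for more inhibition of growth at the one concentration tested and lower numbers for less inhibition of growth:
compound 1, `C=CCc1ccc(OCc2cn(-c3ccc(C#N)cc3)nn2)c(O)c1`, gives 35.7%
compound 2, `C=CCc1ccc(OCc2cn(-c3ccc(OC)cc3)nn2)c(O)c1`, gives 38.8%

Compound 2 holds the higher of the two numbers in this assay, but its nearest neighbour, compound 1, sits close enough that the two cannot be told apart: the step of a number 3.1 percentage points higher from compound 1 to compound 2 (within the scatter) lies within the scatter.

Next in the series is compound 3, `C=CCc1ccc(OCc2cn(-c3ccc(C(=O)c4ccccc4)cc3)nn2)c(O)c1`. It differs from compound 2 in one place: benzoyl in place of methoxy on an aromatic carbon. The change sits on the same aromatic carbon that was varied between compound 1 and compound 2.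

Within the data shown here, only one measured step bears on it, the exchange of the cyano for the methoxy group at that carbon, which left the read-out unchanged beyond the scatter (a number 3.1 percentage points higher from compound 1 to compound 2 (within the scatter)). The benzoyl group is a larger substituent than either, but nothing in the two measured compounds indicates that changes at this position move the number. The expectation for compound 3 is therefore a step of about a number 0.8 percentage points lower from compound 2 to compound 3 (within the scatter), which is no change beyond the scatter. On that basis compound 3 is estimated at 38% in this assay, in the range 20% to 56%.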

Compound 3, percent growth inhibition at one concentration: 40.3%
Compound 3: the middle estimate sits 2.3 percentage points below what was measured; the measured number falls inside the stated range.
By their numbers in this assay, from the lowest: compounds 1, 2 and 3 (each within the scatter of the next).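

The benzoyl group brings a further six-membered aromatic ring of carbon only to this aromatic carbon, para to a large group, yet this assay shows a number 1.5 percentage points higher from compound 2 to compound 3 (within the scatter), and against the cyano compound it shows a number 4.6 percentage points higher from compound 1 to compound 3 (within the scatter). The earlier pair showed only that two small substituents could not be told apart here; this result extends that to a much larger group, so size alone, across these three substituents, does not separate the compounds in this read-out. No measurement at hand bears on why the number stays flat at this position.

As far as these compounds go, whether a group of another kind on this aromatic carbon, such as an amine or a carboxylic acid, would move the number beyond the scatter remains open, as does whether a change elsewhere on the shared core, such as a longer chain, would do so. From the compounds shown here alone, all three numbers also come from a single tested concentration, so whether these compounds would separate at other concentrations is still unknown.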